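The source may hold more compounds than are shown below. What is called first, only, known or untested is meant among the compounds shown, and "the series" means these compounds.

Compound 1 `NC(=O)C(=O)NCCCCCC(=O)Nc1ccccc1` is tested in a functional assay on HCT-116 cells (Homo sapiens) for inhibition, read by colorimetric assay, with a stated time of 3 days; a lower number here means a stronger inhibitor, a higher number a weaker inhibitor. In this assay compound 1 gives > 100000 nM, which is a limit and not a number. Compound 2 `O=C(CCCCCCNC(=O)C(O)(O)C(F)(F)F)Nc1ccc(C(=O)c2ccccc2)cc1`, built differently, gives > 40000 nM in this assay, and this too is a limit. Among the compounds with values here, neither compound therefore provides a measured number, and no measured step between close relatives is available to set a scale.

Compound 3 `CC(=O)C(=O)NCCCCCC(=O)Nc1ccccc1` keeps the core of compound 1 and changes one group: methyl in place of amino on a carbonyl carbon. In words, this is methyl in place of amino on a carbonyl carbon, so that carbamoyl becomes acetyl. Within the data shown here, with no measured step as a guide, only a small change can reasonably be expected, perhaps none beyond the scatter. Expected here is an at least 1.4-fold lower number from compound 1 to compound 3 (0.15 log units; that floor lies within the scatter), at best a modest move toward a stronger inhibitor, and another limit is quite possible. For compound 3 the estimated value is 70000 nM, with an expected range from 20000 nM to 200000 nM.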

Compound 3, half-maximal inhibitory concentration: > 100000 nM
Compound 3 was reported as a limit; the forecaster's own chance of this, stated with the estimate: 60%; middle value at least 1.4-fold (0.15 log units) from the limit.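

Compound 1 and compound 3 are both reported only as limits in this assay, so no step can be read from the change of amino to methyl: the limit of > 100000 nM in this assay, at which 2 of the 3 values shown sit.

The compounds shown leave open what actual number compound 1, compound 2 or compound 3 would give in this assay, and whether methyl or amino on this carbonyl carbon makes any difference.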